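Alpha-hydroxylation of the isopropyl amide in the MKN-45 series

A few compounds are considered here, and "the series" means these few. Any claim that something is new, unique, unknown or untested is made for them only; others in the source may bear on it.

Three amides sharing one core have been measured so far. Compound 1 `CCCCC(=O)Nc1cc(Oc2ccc(Nc3nccc4[nH]cc(-c5ccc(F)cc5)c(=O)c34)cc2F)ccn1` gives 62.7% in a functional assay on MKN-45 cells (Homo sapiens) for antiproliferative activity, read by MTT assay, with a stated time of 72 h, tested at 10 uM; a higher number here means more inhibition at the concentration tested (going by the name of the read-out), a lower number less inhibition. Compound 2 `CCC(=O)Nc1cc(Oc2ccc(Nc3nccc4[nH]cc(-c5ccc(F)cc5)c(=O)c34)cc2F)ccn1` gives 92.1% in this assay, and compound 3 `CC(C)C(=O)Nc1cc(Oc2ccc(Nc3nccc4[nH]cc(-c5ccc(F)cc5)c(=O)c34)cc2F)ccn1` gives 95.4%. Compound 3 stands highest of the three numbers, though the step of a number 3.3 percentage points higher from compound 2 to compound 3 (within the scatter) lies within the scatter, so the two cannot be ordered; the step of a number 32.7 percentage points higher from compound 1 to compound 3 (beyond the scatter) is large and beyond the scatter, as is a number 29.4 percentage points higher from compound 1 to compound 2 (beyond the scatter).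

The next compound, compound 4 `CC(C)(O)C(=O)Nc1cc(Oc2ccc(Nc3nccc4[nH]cc(-c5ccc(F)cc5)c(=O)c34)cc2F)ccn1`, differs from compound 3 in one place: hydroxy in place of hydrogen on a saturated chain carbon bound to a carbonyl carbon and two saturated chain carbons. Among the compounds with values here, no measured step introduces a hydroxy group anywhere. Within the data shown here, the only step at the same carbon is a number 3.3 percentage points higher from compound 2 to compound 3 (within the scatter), which stayed within the scatter, so the measured data give no basis for a step beyond the scatter here. Because compound 3 gives 95.4%, which leaves little room above it, compound 4 is expected at 90% in this assay, within 75% to 98%, a step of a number 5.4 percentage points lower from compound 3 to compound 4 (within the scatter) estimated from compound 3 to compound 4.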

Compound 4, a percentage reported as inhibition, at one concentration (the size of the read-out at that concentration, not a potency): 57.8%
Estimate against measurement, compound 4: 32.2 percentage points above, and the stated range ends above it.
By their numbers in this assay, from the lowest: compounds 4 and 1 (each within the scatter of the next); then compounds 2 and 3 (each within the scatter of the next).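

Notes on this assay: this carbon is not indifferent to what it carries. Methyl in place of hydrogen gave a number 3.3 percentage points higher from compound 2 to compound 3 (within the scatter), whereas hydroxy in place of hydrogen gives a number 37.6 percentage points lower from compound 3 to compound 4 (beyond the scatter). Measured against ethyl on the carbonyl carbon, the 1-hydroxy-1-methylethyl group gives a number 34.3 percentage points lower from compound 2 to compound 4 (beyond the scatter), and against butyl it gives a number 4.9 percentage points lower from compound 1 to compound 4 (within the scatter), so two structurally different groups on the carbonyl carbon end within the scatter of each other. Nothing available accounts for the loss on adding the hydroxy group.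

The compounds shown leave open whether the loss is specific to hydroxy or would also follow from a methoxy group or an amine on the same carbon. They also leave open whether hydroxy on the ethyl chain of compound 2 would give a similar step.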